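A few compounds are considered here, and "the series" means these few. Any claim that something is new, unique, unknown or untested is made for them only; others in the source may bear on it.

Working notes on the series. The shared core of compound 1 `CC(C)OC(=O)N1CCC2(CC1)CC(CCCOc1ccc(S(C)(=O)=O)cc1)C2` carries a methylsulfonyl on the aromatic ring; in a functional assay on cells for agonist activity at Glucose-dependent insulinotropic receptor (Homo sapiens), read by HTRF and cAMP accumulation, with a stated time of 30 min (on this read-out higher numbers stand for an effect only at larger amounts of compound and lower numbers for an effect already at smaller amounts), compound 1 gives 78 nM. Compound 2 `CC(C)OC(=O)N1CCC2(CC1)CC(CCCOc1ccc(S(C)(=O)=O)c(F)c1)C2` adds a fluoro on an aromatic carbon, and in this assay compound 2 gives 18 nM, the lowest number of the three measured; the step of a 4.3-fold lower number from compound 1 to compound 2 (0.64 log units; beyond the scatter) lies beyond the scatter. Compound 3 `CS(=O)(=O)c1ccc(OCCCC2CC3(CCN(C(=O)OC4CCCC4)CC3)C2)cc1F` replaces the isopropyl with a cyclopentyl on the oxygen next to the carbonyl, and in this assay compound 3 gives 23 nM; the step of a 1.3-fold higher number from compound 2 to compound 3 (0.11 log units; within the scatter) is within the scatter, so compound 2 and compound 3 are not separated.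

Compound 4 `CC(C)OC(=O)N1CCC2(CC1)CC(CCCOc1ccc(C(=O)NC3CC3)c(F)c1)C2` differs from compound 2 by cyclopropylcarbamoyl in place of methylsulfonyl on an aromatic carbon. Within the data shown here, neither measured step touches this group: the fluoro step and the carbamate step leave the methylsulfonyl in place, so no precedent for this exchange exists in the data. The expectation therefore rests on compound 2 alone, with a wide range. Compound 4 is estimated at 45 nM in this assay, between 10 nM and 200 nM, an expected step of a 2.5-fold higher number from compound 2 to compound 4 (0.40 log units; beyond the scatter).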

Compound 4, half-maximal effective concentration: 8 nM
The estimate for compound 4 lay 5.6-fold (0.75 log units) above the measured number; the whole stated range lies above it.
By their numbers in this assay, from the lowest: compound 4; then compounds 2 and 3 (each within the scatter of the next); then compound 1.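

At the aromatic carbon para to a large group, the methylsulfonyl had stayed fixed in all earlier compounds; with the ortho fluoro group kept, cyclopropylcarbamoyl is tolerated there, and in this assay the exchange gives a 2.3-fold lower number from compound 2 to compound 4 (0.35 log units; beyond the scatter). A low number on this read-out therefore does not depend on the methylsulfonyl, at least in compound 4. The entering group brings a hydrogen-bond donor and a three-membered ring, but nothing available ties the step to either feature or gives any other explanation for it.

The compounds shown leave open whether the fluoro step and the cyclopentyl exchange carry over to the cyclopropylcarbamoyl compounds. They also leave open whether an unsubstituted carbamoyl, a cyclobutylcarbamoyl or a nitrile at this position would give a similar number.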